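The source may report more compounds than this note shows. Statements on the series, on what has been measured and on what is new or still open speak of the compounds shown alone.

Compound 1 `FC(F)(F)c1cccc(NC(=S)Nc2ccc(Cl)cc2)c1` gives 6800 nM in an ADME assay on MT4 cells (Homo sapiens) for cytotoxicity (on this read-out lower numbers stand for higher toxicity in this test and higher numbers for lower toxicity in this test), the lowest number among the three compounds measured. Compound 3 `Fc1ccccc1NC(=S)Nc1cccc(C(F)(F)F)c1` gives 47000 nM. Compound 2 `CCNC(=S)Nc1cccc(C(F)(F)F)c1` gives > 100000 nM, which is a limit of the assay and not a number. Compound 4 `CCOC(=O)c1ccc(NC(=S)Nc2cccc(C(F)(F)F)c2)cc1` keeps the core of compound 1 but carries ethoxycarbonyl in place of chloro on an aromatic carbon, para to a large group: ethoxycarbonyl in place of chloro on an aromatic carbon. Among the measured compounds shown here, no measured step makes this exchange on its own. The nearest evidence comes from two steps that replace the whole 4-chlorophenyl. Putting 2-fluorophenyl there gives a 6.9-fold higher number from compound 1 to compound 3 (0.84 log units; beyond the scatter), and putting ethyl there gives an at least 14-fold higher number from compound 1 to compound 2 (1.16 log units; beyond the scatter). Both steps raise the number, so a modest rise rather than a drop is expected here, on the scale of the smaller step, a 6.9-fold higher number from compound 1 to compound 3 (0.84 log units; beyond the scatter). The expected step is a 2.9-fold higher number from compound 1 to compound 4 (0.47 log units; beyond the scatter), though this rests on indirect evidence. For compound 4 the estimate is 20000 nM, with an expected range from 5000 nM to 80000 nM.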

Compound 4, half-maximal cytotoxic concentration: 23000 nM
Compound 4: the middle estimate sits 1.2-fold (0.06 log units) below what was measured; the measured number falls inside the stated range.
By their numbers in this assay, from the lowest: compound 1; then compound 4; then compound 3. At a limit, above all of these: compound 2.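

Among the compounds shown here, compound 4 is the first compound here to keep the rest of compound 1 and change only the group on this aromatic carbon, whereas the earlier steps replaced the whole 4-chlorophenyl. In this assay, this single exchange of chloro for ethoxycarbonyl gives a 3.4-fold higher number from compound 1 to compound 4 (0.53 log units; beyond the scatter), so a change at this position alone moves the number beyond the scatter, and in the same direction as those larger replacements. Compound 2 stands at a limit of the assay and not at a number, while the step to compound 4 has a measured size at both ends: the limit of > 100000 nM in this assay, at which 1 of the 4 values shown sits.

The compounds shown leave open whether the rise goes with the loss of chloro or with the entry of ethoxycarbonyl. On these data alone, how a carboxylic acid or an amine on this aromatic carbon would read also remains open.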